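A few compounds are considered here, and "the series" means these few. Any claim that something is new, unique, unknown or untested is made for them only; others in the source may bear on it.

Compound 1 `Cc1ccc(NC(=O)c2cnc(Cl)nc2C(F)(F)F)s1` gives 2800 nM in an assay on Jurkat cells for inhibition of cyclic AMP-dependent transcription factor ATF-1 (Homo sapiens); a higher number here means a weaker inhibitor, a lower number a stronger inhibitor. Compound 2 `O=C(Nc1cc(C(F)(F)F)cc(C(F)(F)F)c1)c1cnc(Cl)nc1C(F)(F)F` gives 50 nM in this assay. Within the data shown here, compound 3 `CCCCNC(=O)c1cc(NC(=O)c2cnc(Cl)nc2C(F)(F)F)cc(C(F)(F)F)c1` gives no number in this assay but only a limit, > 10000 nM, and it is the one value in the set sitting at the limit of > 10000 nM in this assay, at which 1 of the 3 values shown sits. So compound 3 stands at the weak end of everything measured; the step of an at least 200-fold higher number from compound 2 to compound 3 (2.30 log units; beyond the scatter) is the only measured change on that aromatic carbon and it was large and in the weaker direction.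

Compound 4 `CCCCCCOC(=O)c1cc(NC(=O)c2cnc(Cl)nc2C(F)(F)F)cc(C(F)(F)F)c1` carries the change (hexyloxy in place of butylamino on a carbonyl carbon). Among the measured compounds shown here, no measured step covers an ester against an amide at this carbonyl, so the only bearing is indirect: the arm on that aromatic carbon has once been altered and the cost was large. Compound 4 is therefore expected to stay near the limit, around 10000 nM, with a range from 2000 nM to 40000 nM. The step of a number no higher from compound 3 to compound 4 (the limit leaves the size open) is the expected change, though with compound 3 at a limit any movement is uncertain.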

Compound 4, half-maximal inhibitory concentration: 660 nM
Compound 4: the middle estimate sits 15-fold (1.18 log units) above what was measured; the whole stated range lies above it.
By their numbers in this assay, from the lowest: compound 2; then compound 4; then compound 1. At a limit, above all of these: compound 3.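

The arm on this carbonyl carbon matters a great deal in this assay: there is an at least 15-fold lower number from compound 3 to compound 4 (1.18 log units; beyond the scatter), so the loss seen with butylcarbamoyl does not extend to every carbonyl-linked group at this place. From the compounds shown here alone, compound 3 stands at a limit of the assay, not at a number, so the size of that step stays open: the limit of > 10000 nM in this assay, at which 1 of the 4 values shown sits. Hexyloxycarbonyl still does not recover what trifluoromethyl gives on this aromatic carbon, with a 13-fold higher number from compound 2 to compound 4 (1.12 log units; beyond the scatter).

Butylamino and hexyloxy differ both in the atom bound to the carbonyl carbon and in chain length, so the compounds shown do not separate these two changes; a butyl ester or a hexyl amide would. Going by these compounds, how a carboxylic acid or a methyl ester on this carbonyl carbon would read also remains open.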